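A few compounds are considered here, and "the series" means these few. Any claim that something is new, unique, unknown or untested is made for them only; others in the source may bear on it.

Working notes on the series. In a functional assay on COLO 205 cells (Homo sapiens) for cytotoxicity, read by MTT assay, with a stated time of 48 h (on this read-out higher numbers stand for weaker inhibition and lower numbers for stronger inhibition), compound 1 (`Fc1cccc(-c2nc(Nc3ccc(Cl)cc3)c3cc(F)ccc3n2)c1`) gives 32600 nM. Compound 2 (`Fc1cccc(-c2nc(Nc3ccccc3Cl)c3cc(F)ccc3n2)c1`) gives > 50000 nM, which is a limit of the assay and not a number. Its standing is therefore known only as the limit of > 50000 nM in this assay, at which 1 of the 2 values shown sits.

The next structure is compound 3 (`Oc1ccc(Nc2nc(-c3cccc(F)c3)nc3ccc(F)cc23)cc1`), with 4-hydroxyphenyl in place of 2-chlorophenyl on a nitrogen on an aromatic ring. The core is unchanged.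

Going by the values given here, one measured step bears on this position, an at least 1.5-fold higher number from compound 1 to compound 2 (0.18 log units; that floor lies within the scatter), with 2-chlorophenyl in place of 4-chlorophenyl. Its size is only a floor, and it does not establish a real difference. Among the compounds with values here, no measured step covers a 4-hydroxyphenyl group, so the expectation is loose.

Within the data shown here, a modest step towards a lower number is expected in this assay, since compound 1 at 32600 nM is the only measured number. The step expected is an at least 2.0-fold lower number from compound 2 to compound 3 (0.30 log units; that floor lies within the scatter). For compound 3 the estimated value is 25000 nM, within an expected range of 8000 nM to 50000 nM.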

Compound 3, half-maximal inhibitory concentration: > 50000 nM
Compound 3: no number, only a limit; the forecaster's own chance of this, stated with the estimate: 35%; at least 2.0-fold (0.30 log units) between middle value and limit.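

In this assay, compound 3 sits at the limit of the assay, as compound 2 does, so neither 2-chlorophenyl nor 4-hydroxyphenyl on this nitrogen yields a number, and the step between these two limits cannot be read. Hydroxy in place of chloro on an aromatic carbon gives an at least 1.5-fold higher number from compound 1 to compound 3 (0.18 log units; that floor lies within the scatter), so this second change at the position, like the first, does not establish a real difference from compound 1. The series now shows more of its values at the ceiling than as numbers: the limit of > 50000 nM in this assay, at which 2 of the 3 values shown sit.

As far as these compounds go, it remains open whether any group at this position gives a value clearly lower than that of compound 1 at 32600 nM, for instance an amine or a carboxylic acid in place of the hydroxy on the aromatic carbon. With only floors available, the compounds shown also do not tell how far compound 2 and compound 3 actually lie from compound 1, or whether the place of the chloro matters at all.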